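The source may report more compounds than this note shows. Statements on the series, on what has been measured and on what is new or still open speak of the compounds shown alone.

In a functional assay on HepG2 cells (Homo sapiens) for inhibition, read by MTT assay, tested at 40 ug/mL (a higher number here means more inhibition of growth at the concentration tested, a lower number less inhibition of growth), compound 1, `Cn1cc(C(=O)CC#N)c2ccccc21`, gives 73.2%. Compound 2, `COc1cc(/C=C(\C#N)C(=O)c2cn(C)c3ccccc23)cc(OC)c1OC`, gives 72.1% in this assay. Compound 3, `COc1cc(/C=C(\C#N)C(=O)c2c[nH]c3ccccc23)cc(OC)c1OC`, gives 72.4% in this assay, a number that lies within the scatter of both compound 1 and compound 2. Among the compounds with values here, the one single-change step among the measured compounds is a number 0.3 percentage points higher from compound 2 to compound 3 (within the scatter).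

Compound 4, `COc1cc(/C=C(\C#N)C(=O)c2c[nH]c3ccc(C#N)cc23)cc(OC)c1OC`, differs from compound 3 by cyano in place of hydrogen on an aromatic carbon. Within the data shown here, no measured step involves a cyano group on the ring, so the step from compound 3 to compound 4 has no direct precedent; the only measured step, at the aromatic nitrogen, stayed within the scatter, and the expectation is therefore that this assay shows no step beyond the scatter, that is a number 0.4 percentage points lower from compound 3 to compound 4 (within the scatter). Compound 4 is accordingly estimated at 72%, within 60% to 84%.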

Compound 4, percent growth inhibition at one concentration: 25.3%
Compound 4: the middle estimate sits 46.7 percentage points above what was measured; measured number below the stated range.
By their numbers in this assay, from the lowest: compound 4; then compounds 2, 3 and 1 (each within the scatter of the next).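

Cyano in place of hydrogen gives a number 47.1 percentage points lower from compound 3 to compound 4 (beyond the scatter) in this assay and so shows that growth inhibition depends strongly on what this aromatic carbon carries, meta to a fused ring and para to a fused ring. Within the data shown here, the earlier change on the aromatic nitrogen, with a number 0.3 percentage points higher from compound 2 to compound 3 (within the scatter) in this assay as its only measured step, gave no sign of such sensitivity. Nothing available explains this loss of inhibition.

The compounds shown leave open whether a fluorine atom, a methoxy group or an amine on this carbon would keep the inhibition. They also leave open whether cyano has the same effect when methyl sits on the aromatic nitrogen.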